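The source may hold more compounds than are shown below. What is called first, only, known or untested is meant among the compounds shown, and "the series" means these compounds.

Compound 1 `CC(C)(C)c1ccc(C(=O)NCc2ccc(S(N)(=O)=O)cc2)cc1` carries a sulfamoyl group on one of its aromatic rings. In an assay on HeLa cells with Bile acid receptor (Homo sapiens) as the target, read by a luciferase reporter, with a stated time of 24 h (a lower number here means that less compound is needed, a higher number that more compound is needed for the effect), compound 1 gives 1400 nM, the highest of the two numbers recorded so far. The other measured compound, compound 2 `Cc1cc(CNC(=O)c2ccc(C(C)(C)C)cc2)ccc1C(=O)O`, carries a carboxylic acid and a methyl group in place of the sulfamoyl, and in this assay compound 2 gives 160 nM, a gap well beyond the usual scatter. Compound 3 `CC(C)(C)c1ccc(C(=O)NCc2ccc(NS(C)(=O)=O)cc2)cc1` has not yet been measured. It departs from compound 1 by one change: methanesulfonamido in place of sulfamoyl on an aromatic carbon. Among the measured compounds shown here, no measured pair shows this exact change, so the expectation rests on compound 1 already standing at the weak end with 1400 nM, while compound 2 with 160 nM shows that a different group on that aromatic ring can lower the number greatly. The expected step is small, a 1.4-fold lower number from compound 1 to compound 3 (0.15 log units; within the scatter), at the edge of the scatter and pointing toward a lower number. Compound 3 is expected to give 1000 nM in this assay, within a range from 300 nM to 3500 nM.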

Compound 3, half-maximal effective concentration: 44 nM
Estimate against measurement, compound 3: 23-fold (1.36 log units) above, outside the stated range (below it).
By their numbers in this assay, from the lowest: compound 3; then compound 2; then compound 1.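

In this assay, methanesulfonamido in place of sulfamoyl on an aromatic carbon, para to a large group, gives a 32-fold lower number from compound 1 to compound 3 (1.50 log units; beyond the scatter), a large step and well beyond the scatter, so what sits at this one place on the ring has a strong hold on the number. The step is striking given how little the counted features differ: both groups carry the same numbers of hydrogen-bond donors and acceptors and no net charge, and the entering group has just one more heavy atom, a carbon, while the ring is bound to nitrogen in compound 3 instead of to sulfur in compound 1. Nothing measured here on these compounds accounts for the size of this step.

An ethanesulfonamido group or a plain amine on that same aromatic carbon would help to separate the part played by the methyl from the part played by the nitrogen on the ring, and the compounds shown leave that open. This single pair also cannot say whether the same change would lower the number on a ring that also carries a methyl group.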